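The source may report more compounds than this note shows. Statements on the series, on what has been measured and on what is new or still open speak of the compounds shown alone.

Within the data shown here, in a functional assay on C8166 cells (Homo sapiens) for cytotoxicity, read by MTT assay (on this read-out lower numbers stand for higher toxicity in this test and higher numbers for lower toxicity in this test), compound 1 (`Cc1cc(S(N)(=O)=O)ccc1NC(=O)COc1ccc(Cl)cc1NC(=O)c1ccccc1C`) gives 67300 nM and compound 2 (`Cc1cc(S(N)(=O)=O)ccc1NC(=O)COc1ccc(Cl)cc1NC(=O)c1ccc(Cl)c(Cl)c1`) gives 158000 nM, which makes compound 2 the higher of the two numbers so far. Compound 3 (`Cc1cc(S(N)(=O)=O)ccc1NC(=O)COc1ccc(Cl)cc1NC(=O)c1cccc2ccccc12`) keeps the shared core but has naphthalen-1-yl in place of 3,4-dichlorophenyl on a carbonyl carbon. Among the measured compounds shown here, only one measured step bears on this change. That step, a 2.3-fold higher number from compound 1 to compound 2 (0.37 log units; beyond the scatter), is modest and also alters the group on that carbonyl carbon. For the measured compounds named here, no measured compound carries naphthalen-1-yl, so this step is only a rough guide to size. Compound 2 stands at the top of the narrow span seen so far, and a modest move to a lower number in this assay is expected. The estimate amounts to a 1.5-fold lower number from compound 2 to compound 3 (0.18 log units; within the scatter), an expected step that may not clear the usual scatter. For compound 3, the estimated value is 105000 nM, with an expected range of 50000 nM to 220000 nM.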

Compound 3, half-maximal cytotoxic concentration: > 381000 nM
Compound 3 ended at the assay's limit; the forecaster's own chance of this, stated with the estimate: 15%; middle value at least 3.6-fold (0.55 log units) from the limit.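

Placing naphthalen-1-yl on this carbonyl carbon gives, in this assay, an at least 2.4-fold higher number from compound 2 to compound 3 (0.38 log units; beyond the scatter), and against 2-methylphenyl the same group gives an at least 5.6-fold higher number from compound 1 to compound 3 (0.75 log units; beyond the scatter). Naphthalen-1-yl carries no chlorine, so chlorine on this group is not required for a higher number than that of compound 1, and the larger carbon-only group of two aromatic rings reads highest of the three. The reading for compound 3 is a limit of the assay and not a number: the limit of > 381000 nM in this assay, at which 1 of the 3 values shown sits.

As far as these compounds go, how far past that limit compound 3 would read remains unknown, so the full size of both steps stays open. The compounds shown also leave open how a saturated ring such as cyclohexyl, or a group bearing an amine or a carboxylic acid, would read on this carbonyl carbon.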